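Replacing an Ester Side Chain with a Methoxyethyl Ether

The source may hold more compounds than are shown below. What is called first, only, known or untested is meant among the compounds shown, and "the series" means these compounds.

Compound 1 `CC(C)=CC[C@@H](OC[C@@H](C)O)C1=CC(=O)c2c(O)ccc(O)c2C1=O`: 22500 nM
Compound 2 `CCCC(O)CC(=O)O[C@H](CC=C(C)C)C1=CC(=O)c2c(O)ccc(O)c2C1=O`: 59300 nM
Compound 3 `CCCC(C)(O)CC(=O)O[C@H](CC=C(C)C)C1=CC(=O)c2c(O)ccc(O)c2C1=O`: 72000 nM

All three numbers come from a functional assay on HeLa cells (Homo sapiens) for cytotoxicity, read by MTT assay; a higher number here means a weaker inhibitor, a lower number a stronger inhibitor. Compound 3 stands highest of the three: against compound 2 the step is a 1.2-fold higher number from compound 2 to compound 3 (0.08 log units; within the scatter), while against compound 1 it is a 3.2-fold higher number from compound 1 to compound 3 (0.51 log units; beyond the scatter). Compound 4 `COCCO[C@H](CC=C(C)C)C1=CC(=O)c2c(O)ccc(O)c2C1=O` keeps the shared core and the chain on the saturated carbon but carries a different group on the oxygen: 2-methoxyethyl in place of (2-hydroxy-2-methylpentyl)carbonyl on an oxygen on a saturated carbon.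

Within the data shown here, two measured steps bear on this. In compound 1 the same oxygen carries a 2-hydroxypropyl ether, and putting an ester there gave a 2.6-fold higher number from compound 1 to compound 2 (0.42 log units; beyond the scatter) and a 3.2-fold higher number from compound 1 to compound 3 (0.51 log units; beyond the scatter). The change to compound 4 runs the other way, from an ester back to an ether, so the number is expected to fall toward that of compound 1, about a 2.9-fold lower number from compound 3 to compound 4 (0.46 log units; beyond the scatter). Compound 4 is therefore estimated at 25000 nM, with a range of 10000 nM to 60000 nM.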

Compound 4, half-maximal inhibitory concentration: 62400 nM
Compound 4: middle estimate off by 2.5-fold (0.40 log units), on the low side, outside the stated range (above it).
By their numbers in this assay, from the lowest: compound 1; then compounds 2, 4 and 3 (each within the scatter of the next).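

Replacing the ester on this oxygen with 2-methoxyethyl in this assay gives a 1.2-fold lower number from compound 3 to compound 4 (0.06 log units; within the scatter) and, for the other ester, a 1.1-fold higher number from compound 2 to compound 4 (0.02 log units; within the scatter) so an ether here does not by itself set a compound apart from the esters. The gap lies instead between the two ethers: methoxymethyl in place of 1-hydroxyethyl on the saturated chain carbon gives a 2.8-fold higher number from compound 1 to compound 4 (0.44 log units; beyond the scatter) and leaves compound 1 alone at the low end of the set. Nothing measured here accounts for that difference between the two ethers.

On these data alone, whether the hydroxy of the 2-hydroxypropyl ether alone carries the gap stays open, and a plain propyl ether or a 2-hydroxyethyl ether would bear on that. Also open, as far as these compounds go, is how an amine or a carboxylic acid on this ether chain would read in this assay.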